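Dichlorophenyl analog in a cytotoxicity series

The source may report more compounds than this note shows. Statements on the series, on what has been measured and on what is new or still open speak of the compounds shown alone.

The measured compounds and their values:
compound 1, `Cc1ccc(C2C(C#N)=C(N)N(c3ccc(S(N)(=O)=O)cc3)C3=C2CCCC3)cc1`, 90%
compound 2, `COc1ccccc1C1C(C#N)=C(N)N(c2ccc(S(N)(=O)=O)cc2)C2=C1CCCC2`, 100%
compound 3, `N#CC1=C(N)N(c2ccc(S(N)(=O)=O)cc2)C2=C(CCCC2)C1c1ccccc1Cl`, 10%

In a functional assay on Ehrlich cells (Mus musculus) for cytotoxicity, read by trypan blue exclusion, with a stated time of 2 h, tested at 100 ug/mL (a higher number here means a stronger effect of the compound at the concentration tested, a lower number a weaker effect), compound 3 gives the lowest of the three numbers. The nearest is compound 1, reached by the step of a number 80 percentage points lower from compound 1 to compound 3 (beyond the scatter), and the furthest is compound 2, reached by the step of a number 90 percentage points lower from compound 2 to compound 3 (beyond the scatter); both gaps lie beyond the scatter. Compounds 1 and 2 sit close together, a number 10 percentage points higher from compound 1 to compound 2 (within the scatter).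

Compound 4, `N#CC1=C(N)N(c2ccc(S(N)(=O)=O)cc2)C2=C(CCCC2)C1c1ccc(Cl)c(Cl)c1`, has not yet been measured. It differs from compound 3 in one place: 3,4-dichlorophenyl in place of 2-chlorophenyl on a saturated ring carbon. Among the measured compounds shown here, the steps that bear on this change are those that alter the same aryl group: a number 80 percentage points lower from compound 1 to compound 3 (beyond the scatter) and a number 90 percentage points lower from compound 2 to compound 3 (beyond the scatter). Both are large, but neither tests a 3,4-dichlorophenyl, so the data do not fix the direction for compound 4. Given that every other aryl group in the set gave a high number in this assay, and only compound 3 gave a low one, compound 4 is estimated to move upward from compound 3, as the step of a number 40 percentage points higher from compound 3 to compound 4 (beyond the scatter). The estimated value for compound 4 is 50%, within the range 5% to 95%, and the uncertainty is wide.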

Compound 4, a percentage reported as activity, at one concentration (the size of the read-out at that concentration, not a potency): 50%
Beside the measured number, compound 4's estimate shows no gap at the digits printed, and the stated range covers the measured number.
By their numbers in this assay, from the lowest: compound 3; then compound 4; then compounds 1 and 2 (each within the scatter of the next).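

In this assay, the aryl group on the saturated ring carbon next to the ring atom that bears a cyano group now gives a third, intermediate level: there is a number 40 percentage points higher from compound 3 to compound 4 (beyond the scatter) on the change to 3,4-dichlorophenyl, while there is also a number 40 percentage points lower from compound 1 to compound 4 (beyond the scatter) and a number 50 percentage points lower from compound 2 to compound 4 (beyond the scatter) in this comparison. The low number of compound 3 therefore does not hold for every chlorinated aryl group at this position, and the two chlorinated compounds stand well apart. Even so, both compound 3 and compound 4 lie under compounds 1 and 2, so among these four compounds the 4-methylphenyl and 2-methoxyphenyl groups give the highest numbers, with no compound going against that order.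

The change from 2-chlorophenyl to 3,4-dichlorophenyl alters both the placing and the count of chlorine in one step, so the compounds shown cannot separate these two contributions, which a 4-chlorophenyl or 3-chlorophenyl group would address. Also open, going by these compounds, is whether an aryl group carrying an amine or a carboxylic acid would fit this order, and all of these readings come from a single concentration. Nothing available here accounts for these differences.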